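Chloro to nitro, repeated on a second core

A few compounds are considered here, and "the series" means these few. Any claim that something is new, unique, unknown or untested is made for them only; others in the source may bear on it.

Of the compounds shown here, three have so far been tested in an assay on isolated protein for inhibition of Aromatase (Homo sapiens), read by fluorescence and colorimetric assay, with a stated time of 30 min; a higher number here means a weaker inhibitor, a lower number a stronger inhibitor. Compound 1 `N#Cc1ccc(C(c2ccc(C#N)cc2)n2cc(COc3ccc(Cl)cc3)nn2)cc1` gives 16100 nM in this assay. Compound 2 `N#Cc1ccc(C(c2ccc(C#N)cc2)n2cc(COc3ccc([N+](=O)[O-])cc3)nn2)cc1` carries, relative to compound 1, (nitro in place of chloro on an aromatic carbon), and in this assay compound 2 gives 7730 nM. The change made a 2.1-fold lower number from compound 1 to compound 2 (0.32 log units; beyond the scatter), a modest but real improvement. Compound 3 `Clc1ccc(OCc2cn(C(c3ccccc3)c3ccccc3)nn2)cc1` is built on a different core; in this assay compound 3 gives 13400 nM, a value that sits within the usual scatter of that of compound 1, so no order between the two can be claimed. The difference between the two cores is not broken down here.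

Compound 4 `O=[N+]([O-])c1ccc(OCc2cn(C(c3ccccc3)c3ccccc3)nn2)cc1` has not yet been measured. It differs from compound 3 by nitro in place of chloro on an aromatic carbon, at the same place as described for the pair of compound 1 and compound 2, so it is the same change carried onto the second core. Within the data shown here, with only one earlier example to lean on, and that on a different core, the expectation is a tentative one. Compound 4 is expected to give about 6500 nM in this assay, with a plausible range from 3000 nM to 14000 nM. For compound 4 this estimate means a 2.1-fold lower number from compound 3 to compound 4 (0.31 log units; beyond the scatter) in this assay, expected because the same change gave a 2.1-fold lower number from compound 1 to compound 2 (0.32 log units; beyond the scatter).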

Compound 4, half-maximal inhibitory concentration: 11600 nM
For compound 4 the middle estimate is 1.8-fold (0.25 log units) below the measured one; low and high end bracket the measured number.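

On the second core, nitro in place of chloro gives a 1.2-fold lower number from compound 3 to compound 4 (0.06 log units; within the scatter) in this assay, so compound 3 and compound 4 cannot be told apart in this assay, whereas the same change on the core of compound 1 gave a modest but real step. Set side by side, the two steps do not differ by more than the normal noise of such measurements allows: the same change on two cores in this assay, a 2.1-fold lower number (0.32 log units; beyond the scatter) from compound 1 to compound 2 and a 1.2-fold lower number (0.06 log units; within the scatter) from compound 3 to compound 4, 1.8-fold (0.26 log units) apart, within the scatter of two such steps. This means the data do not show that the gain seen on the core of compound 1 carries over to the second core, and they do not show that it is lost there either, since both steps are small and a single shared small effect fits them as well as an effect that depends on the core.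

Going by these compounds, only chloro and nitro appear at this place on the ring, so what an amine, a carboxylic acid or a methoxy group would do there stays open. On these data alone, with just two pairs of compounds, it also stays open whether swapping chloro for nitro would give a clear step on a third core, or a larger step with any other group.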